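The source may report more compounds than this note shows. Statements on the series, on what has been measured and on what is new or still open speak of the compounds shown alone.

Of the compounds shown here, two have so far been measured in a physicochemical assay for lipophilicity, read by NMR; on this read-out lower numbers stand for lower lipophilicity and higher numbers for higher lipophilicity. Compound 1 `C[C@H](O)C[C@H](C)F` gives 0.57 in this assay, and compound 2 `OCCC(F)CC(F)(F)F` gives 0.84. These two numbers lie within the usual scatter of one another, so compound 1 stands as one of two closely spaced values, its gap to compound 2 too small to read as a real difference. Compound 3 `C[C@H](O)C[C@@H](C)F` has not yet been measured. Its relation to compound 1 is this: the two compounds have the same atoms and bonds and differ only in configuration as drawn: 1 of 2 stereo elements differ; a stereocentre at a saturated chain carbon is drawn S in compound 1 and R in compound 3. Within the data shown here, no step between measured compounds is recorded for a change of this kind, so the expectation rests on the change itself, which brings in nothing and takes nothing away. Compound 3 is therefore expected to sit where compound 1 sits, because compound 1 gives 0.57 with the same atoms and bonds. The expected step is no change at the digits printed from compound 1 to compound 3 (within the scatter), none beyond the scatter. For compound 3 the estimate in this assay is 0.57, with a range from 0.3 to 0.85.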

Compound 3, partition coefficient: 0.48
Beside the measured number, compound 3's estimate is 0.09 log units above it; low and high end bracket the measured number.
By their numbers in this assay, from the lowest: compounds 3, 1 and 2 (each within the scatter of the next, the first and the last beyond it).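

In this assay, among these compounds, redrawing a stereocentre at a saturated chain carbon from S to R gives a number 0.09 log units lower from compound 1 to compound 3 (within the scatter), the first step in this study that can be read between compounds differing in one place. Compounds 1 and 2 offered no such reading, as their structures differ in more than one place and their gap says nothing about configuration. Among the compounds shown here, at this stereocentre the one change therefore leaves no difference that can be told from the scatter, and the comparison rests on a single fact: the fact that compounds 1 and 3 differ only in the configuration as drawn.

The compounds shown leave open whether redrawing the other stereocentre would also stay within the scatter. They also leave open whether the same change from S to R would read alike on a longer chain or with an amine in place of the hydroxyl.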